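Replacing the 2-fluorophenyl group of compound 1

The source may hold more compounds than are shown below. What is called first, only, known or untested is meant among the compounds shown, and "the series" means these compounds.

compound 1 `COC(=O)CC/C(C)=C/Cc1c(OC)c(C)c2c(c1OCC#CCN1CCN(c3ccccc3F)CC1)C(=O)OC2` in a functional assay on SH-SY5Y cells (Homo sapiens) for inhibition, read by sulforhodamine B assay (a lower number here means a stronger inhibitor, a higher number a weaker inhibitor), gives 35800 nM
compound 2 `CCCCNc1ccc(CC#CCOc2c(C/C=C(\C)CCC(=O)OC)c(OC)c(C)c3c2C(=O)OC3)cc1` gives 5960 nM
compound 3 `COC(=O)CC/C(C)=C/Cc1c(OC)c(C)c2c(c1OCC#CCN1CCC(C(=O)OC)CC1)C(=O)OC2` gives 41200 nM

Compound 1 lies within the scatter of compound 3 and beyond the scatter from compound 2, which has the lowest number of the three. Compound 4 `COC(=O)CC/C(C)=C/Cc1c(OC)c(C)c2c(c1OCC#CCN1CCN(C(=O)C3COc4ccccc4O3)CC1)C(=O)OC2` has not yet been measured. It differs from compound 1 by (2,3-dihydro-1,4-benzodioxin-2-yl)carbonyl in place of 2-fluorophenyl on an amine nitrogen in a ring with (2,3-dihydro-1,4-benzodioxin-2-yl)carbonyl in place of 2-fluorophenyl on an amine nitrogen in a ring.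

Among the compounds with values here, the one measured step that bears on this change is a 6.9-fold higher number from compound 2 to compound 3 (0.84 log units; beyond the scatter) where 4-(methoxycarbonyl)piperidin-1-yl stands in place of 4-(butylamino)phenyl on a saturated chain carbon bound to a triple-bonded carbon. That step is modest, and neither of its groups takes part in the present exchange. Compound 1 and compound 3 carry different end groups yet sit within the scatter of each other, and compound 2 alone stands apart. With compound 3 at 41200 nM and compound 1 at 35800 nM no step beyond the scatter is expected in this assay and no direction can be favoured. The expected step is a 1.2-fold lower number from compound 1 to compound 4 (0.08 log units; within the scatter) and it is estimated to stay within the scatter. For compound 4 the estimated value is 30000 nM with an expected range from 12000 nM to 70000 nM for a later measurement.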

Compound 4, half-maximal inhibitory concentration: > 50000 nM
Compound 4 was reported as a limit; the forecaster's own chance of this, stated with the estimate: 15%; middle value at least 1.6-fold (0.22 log units) from the limit.
By their numbers in this assay, from the lowest: compound 2; then compounds 1 and 3 (each within the scatter of the next). At a limit, above all of these: compound 4.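

In this assay compound 4 is reported only as a limit: the limit of > 50000 nM in this assay, at which 1 of the 4 values shown sits. That limit sets the step at an at least 1.3-fold higher number from compound 1 to compound 4 (0.14 log units; that floor lies within the scatter), so the exchange on the amine nitrogen in the ring, which brings in a larger group with 3 hydrogen-bond acceptors where 2-fluorophenyl has none, gave no lower number. The earlier compounds shown here could not show this, as none of them tests a carbonyl-linked group on this nitrogen, though the floor of the step lies within the scatter and the limit does not tell whether the true step goes beyond it.

The compounds shown leave open whether a much smaller acyl group such as acetyl, or a plain hydrogen on this nitrogen, would give a number different from that of compound 1. They also leave open whether the 2-fluorophenyl group needs its fluorine at all, since an unsubstituted phenyl group on the same nitrogen would separate the part played by the fluorine from that of the aromatic ring.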